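This account rests on a few compounds, and the source may have more. Where it says the series, first, only, none or still open, it means among the compounds named here.

Of the compounds shown here, three built on the same core have been tested in a functional assay on HCC1937 cells (Homo sapiens) for antiproliferative activity, read by CCK-8 assay, with a stated time of 72 h; a higher number here means a weaker inhibitor, a lower number a stronger inhibitor. Compound 1 `COc1ccc(C(=O)Nc2cccc(-c3oc4cc(-c5ccc(F)cc5)ccc4c(=O)c3O)c2)cc1` gives 5490 nM. Compound 2 `Cc1ccc(C(=O)Nc2cccc(-c3oc4cc(-c5ccc(F)cc5)ccc4c(=O)c3O)c2)cc1` gives 7110 nM. Compound 3 `CCc1ccc(C(=O)Nc2cccc(-c3oc4cc(-c5ccc(F)cc5)ccc4c(=O)c3O)c2)cc1` gives 13200 nM. Compound 3 therefore carries the highest number of the three. Of its two gaps, a 2.4-fold higher number from compound 1 to compound 3 (0.38 log units; beyond the scatter) lies beyond the scatter, while a 1.9-fold higher number from compound 2 to compound 3 (0.27 log units; within the scatter) lies within it, as does a 1.3-fold higher number from compound 1 to compound 2 (0.11 log units; within the scatter) between the other two.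

The next compound, compound 4 `O=C(Nc1cccc(-c2oc3cc(-c4ccc(F)cc4)ccc3c(=O)c2O)c1)c1ccc(Cl)nc1`, differs from compound 3 in one place: 6-chloropyridin-3-yl in place of 4-ethylphenyl on a carbonyl carbon. Among the measured compounds shown here, none of the measured steps makes a change of this kind. They only vary the small group carried by the ring that is now exchanged altogether, and each of them moved the number by a modest amount at most. Those steps therefore bear on the new change only loosely, and they give no clear direction. The expectation is a modest step in this assay, which may run either way, written as a 1.7-fold lower number from compound 3 to compound 4 (0.22 log units; within the scatter). Compound 4 is accordingly estimated at about 8000 nM, within a range from 3000 nM to 22000 nM.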

Compound 4, half-maximal inhibitory concentration: 7550 nM
Compound 4: the middle estimate sits 1.1-fold (0.03 log units) above what was measured, within the range that was stated.
By their numbers in this assay, from the lowest: compounds 1, 2, 4 and 3 (each within the scatter of the next, the first and the last beyond it).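

In this assay, exchanging the whole ring on the carbonyl carbon, rather than only the small group it carries, still leaves the number within the scatter of all three earlier compounds: a 1.7-fold lower number from compound 3 to compound 4 (0.24 log units; within the scatter) and a 1.1-fold higher number from compound 2 to compound 4 (0.03 log units; within the scatter) and also a 1.4-fold higher number from compound 1 to compound 4 (0.14 log units; within the scatter) are each too small to count as a real difference. The position therefore accepts 6-chloropyridin-3-yl, a ring with one hetero atom and one hydrogen-bond acceptor, about as readily as the carbon-only rings 4-methoxyphenyl, 4-methylphenyl and 4-ethylphenyl, so these added features bring no clear gain or loss in this assay. Nothing measured here explains this outcome.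

As far as these compounds go, the ring nitrogen and the chlorine enter together, so what each does alone remains open, and a 4-chlorophenyl or an unsubstituted pyridin-3-yl group would separate the two. Also open, from the compounds shown here alone, is how the number responds to a different kind of group on this ring, such as an amine or a carboxylic acid, and whether any group at this position can give a clearly lower number than compound 1, which gives 5490 nM.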